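This account rests on a few compounds, and the source may have more. Where it says the series, first, only, none or still open, it means among the compounds named here.

Of the compounds shown here, two built on the same core have been measured in a functional assay on MCF-A cells (Homo sapiens) for cytotoxicity; on this read-out higher numbers stand for weaker inhibition of growth and lower numbers for stronger inhibition of growth. Compound 1 `COc1ccc(C2=C(c3ccc(SC)cc3)CC3CCCN3C2=O)cc1OC(=O)C1CCCN1C(=O)OC(C)(C)C` gives 4000 nM in this assay, while compound 2 `CSc1ccc(C2=C(c3ccc(C)c(C)c3)C(=O)N3CCCC3C2)cc1` gives 800 nM. Of these two numbers, compound 2 has the lower one, and its gap to compound 1 lies beyond the usual scatter of this assay, so compound 2 is the stronger inhibitor of growth of the pair.

Compound 3 `CSc1ccc(C2=C(c3ccc(C)cc3)C(=O)N3CCCC3C2)cc1` has not yet been measured. It differs from compound 2 in one place only: hydrogen in place of methyl on an aromatic carbon. The change is the loss of a single methyl carbon from an aromatic ring.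

Among the compounds with values here, no measured pair in this set shows the effect of such a change, so there is no direct guide. The step from compound 2 to compound 3 is expected to be small, a 1.4-fold higher number from compound 2 to compound 3 (0.14 log units; within the scatter), and may well fall within the scatter. Compound 3 is therefore estimated at 1100 nM, with a likely range from 450 nM to 2700 nM.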

Compound 3, concentration for 50% growth inhibition: 600 nM
Estimate against measurement, compound 3: 1.8-fold (0.26 log units) above; the range from low to high includes it.
By their numbers in this assay, from the lowest: compounds 3 and 2 (each within the scatter of the next); then compound 1.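

Going from the 3,4-dimethylphenyl group to the 4-methylphenyl group gives a 1.3-fold lower number from compound 2 to compound 3 (0.12 log units; within the scatter) in this assay, so the two compounds cannot be told apart on this read-out. Within the data shown here, this is the first pair in the set that differs in one place, and it shows that growth inhibition in these cells is kept when hydrogen stands in place of the methyl on this aromatic carbon. No measurement available here bears on why the two compounds match.

Hydrogen and methyl are the only two groups compared at this position, so it remains open whether a larger or different group, such as an amine, a carboxylic acid or a longer chain, would be tolerated there as well. Also open, from the compounds shown here alone, is what would happen if the remaining methyl of the 4-methylphenyl group gave way to hydrogen.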